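Vero cytotoxicity notes: aryl change from compound 2 to compound 3

A few compounds are considered here, and "the series" means these few. Any claim that something is new, unique, unknown or untested is made for them only; others in the source may bear on it.

Measured compounds:
compound 1 `C[C@]1(CN2CCc3nc(-c4ccc(F)cc4)oc3C2)Cn2cc([N+](=O)[O-])nc2O1` — > 32 ug/mL
compound 2 `C[C@]1(CN2CCc3nc(-c4ccc(Cl)cc4)ccc3C2)Cn2cc([N+](=O)[O-])nc2O1` — "not determined" (no result reported)

In an ADME assay on Vero cells (Chlorocebus sabaeus) for cytotoxicity, read by MTT assay, with a stated time of 72 h (on this read-out lower numbers stand for higher toxicity in this test and higher numbers for lower toxicity in this test), compound 1 gives > 32 ug/mL, which is a limit of the assay and not a number; the line the limit of > 32 ug/mL in this assay, at which 1 of the 2 values shown sits, records this. Among the measured compounds shown here, compound 2 stands at "not determined" (no result reported) in this assay, so nothing numerical is known for it, and no measured step leads to it or away from it. Compound 3 `C[C@]1(CN2CCc3nc(-c4cc(F)cc(Cl)c4)ccc3C2)Cn2cc([N+](=O)[O-])nc2O1` differs from compound 2 in one place: 3-chloro-5-fluorophenyl in place of 4-chlorophenyl on an aromatic carbon. For the measured compounds named here, with no measured pair, no step size can be drawn from data; the expectation is that the change from compound 2 to compound 3 lies within the scatter of this assay, without direction. For compound 3 the estimate in this assay is 32 ug/mL, with a range from 12 ug/mL to 64 ug/mL, and a limit rather than a number is expected to be the likelier outcome.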

Compound 3, half-maximal cytotoxic concentration: > 32 ug/mL
Compound 3: no number, only a limit; the forecaster's own chance of this, stated with the estimate: 70%; the middle value lies on the limit itself.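

Among the compounds shown here, no step from compound 2 to compound 3 can be read, as compound 2 carries no reported result. In this assay compound 3 gives > 32 ug/mL, a limit and not a number. The compounds shown leave open how the aryl change bears on cytotoxicity.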